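Dropping the Chloro: Cytotoxicity Expected to Stay Beyond Reach

This account rests on a few compounds, and the source may have more. Where it says the series, first, only, none or still open, it means among the compounds named here.

Compound 1 `Clc1ccc(NCc2cn(-c3ccccc3)nc2-c2ccc(Cl)cc2)cc1`: in an ADME assay on MT4 cells (Homo sapiens) for cytotoxicity, read by MTT assay, with a stated time of 96 h (on this read-out lower numbers stand for higher toxicity in this test and higher numbers for lower toxicity in this test), compound 1 gives > 100000 nM, which is a limit of the assay and not a number.
Compound 2 `Cc1ccc(NCc2cn(-c3ccccc3)nc2-c2ccc(Cl)cc2)cc1`: in this assay compound 2 gives > 100000 nM, again a limit of the assay.
Compound 3 `Cc1ccc(-c2nn(-c3ccccc3)cc2CNc2ccc(Br)cc2)cc1`: in this assay compound 3 gives > 100000 nM, also a limit of the assay.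

Compound 1 therefore stands nowhere in particular on a scale: only a limit is known for it in this assay, and the other two measured compounds sit at that same limit (the limit of > 100000 nM in this assay, at which 3 of the 3 values shown sit). Among the compounds with values here, the single step between measured compounds that differ in one place, a step that the two limits leave unreadable from compound 1 to compound 2, cannot be read in size, since both of its ends are limits.

Compound 4 `Clc1ccc(NCc2cn(-c3ccccc3)nc2-c2ccccc2)cc1` differs from compound 1 by hydrogen in place of chloro on an aromatic carbon, so the 4-chlorophenyl becomes a plain phenyl. Within the data shown here, no measured step touches this part of the shared core, and every value so far is a limit, so nothing in the data points to a readable change in either direction. The step from compound 1 to compound 4 is expected to be none beyond the scatter, which is what a step that the limit leaves unreadable from compound 1 to compound 4 means here. Compound 4 is therefore expected to give about 150000 nM, within 50000 nM to 500000 nM, most likely reported again only as a limit.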

Compound 4, half-maximal cytotoxic concentration: > 100000 nM
Compound 4 was reported as a limit; the forecaster's own chance of this, stated with the estimate: 85%; the middle value is on the limit's open side.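

In this assay compound 4 gives > 100000 nM as a limit of the assay and not as a number. The step from compound 1 to compound 4 therefore cannot be read in size, as all values stand at one limit: the limit of > 100000 nM in this assay, at which 4 of the 4 values shown sit. The compounds shown leave open how far each lies beyond that limit, and what change, if any, would give a readable cytotoxic concentration.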